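The source may report more compounds than this note shows. Statements on the series, on what has been measured and on what is new or still open speak of the compounds shown alone.

Measured compounds:
compound 1 `COc1cc2ncnc(Nc3ccc(Cl)cc3)c2cc1OCCCCC(=O)Nc1ccc(S(N)(=O)=O)cc1` — > 40000 nM
compound 2 `COc1cc2ncnc(Nc3cccc(Cl)c3F)c2cc1OCCCCC(=O)Nc1ccc(S(N)(=O)=O)cc1` — 10500 nM

In a functional assay on A549 cells (Homo sapiens) for antiproliferative activity, read by MTT assay, with a stated time of 72 h (a lower number here means a stronger inhibitor, a higher number a weaker inhibitor), compound 1 gives only a limit, > 40000 nM. In this assay, among the measured compounds shown here, compound 2 gives 10500 nM, the only actual number among the two values. The step between them is an at least 3.8-fold lower number from compound 1 to compound 2 (0.58 log units; beyond the scatter). Compound 3 `COc1cc2ncnc(Nc3ccc(OC(F)(F)F)cc3)c2cc1OCCCCC(=O)Nc1ccc(S(N)(=O)=O)cc1` has not yet been tested; the change is 4-(trifluoromethoxy)phenyl in place of 3-chloro-2-fluorophenyl on a nitrogen on an aromatic ring. For the measured compounds named here, the only measured step that bears on it is an at least 3.8-fold lower number from compound 1 to compound 2 (0.58 log units; beyond the scatter), which runs the other way: it left a phenyl carrying one substituent, 4-chlorophenyl, for 3-chloro-2-fluorophenyl. Compound 3 returns to a phenyl with one substituent, 4-(trifluoromethoxy)phenyl, so a step of similar size back toward a higher number is expected, a 2.9-fold higher number from compound 2 to compound 3 (0.46 log units; beyond the scatter). Compound 3 is therefore estimated at 30000 nM, between 8000 nM and 100000 nM, with a fair chance that only a limit is reported.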

Compound 3, half-maximal inhibitory concentration: > 40000 nM
Compound 3: only a limit was reported; the forecaster's own chance of this, stated with the estimate: 40%; middle value at least 1.3-fold (0.12 log units) from the limit.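

In this assay, putting 4-(trifluoromethoxy)phenyl in place of 3-chloro-2-fluorophenyl on a nitrogen on an aromatic ring gives an at least 3.8-fold higher number from compound 2 to compound 3 (0.58 log units; beyond the scatter). Earlier, only 4-chlorophenyl had been seen to fall short of 3-chloro-2-fluorophenyl here; now two different phenyl groups with one substituent do, and among these three compounds only the phenyl carrying both chlorine and fluorine gives an actual number. The other two compounds cannot be ranked against each other, and the steps to them give only a minimum size, because both values are limits: the limit of > 40000 nM in this assay, at which 2 of the 3 values shown sit.

The compounds shown do not separate the chlorine from the fluorine, so 3-chlorophenyl or 2-fluorophenyl on the same nitrogen remains an open case. Also open, from the compounds shown here alone, is whether a longer chain in the shared core would move compound 2 from 10500 nM.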